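Methyl to carboxy: what compound 4 may show

The source may hold more compounds than are shown below. What is called first, only, known or untested is meant among the compounds shown, and "the series" means these compounds.

Compound 1 `Cc1ccc(/N=C2\C(=O)Nc3ccc(S(=O)(=O)N4CCOCC4)cc32)cc1` gives 309000 nM
Compound 2 `COc1ccc(-c2c(C#N)c(N)n(/N=C3\C(=O)Nc4ccc(S(=O)(=O)N5CCOCC5)cc43)c(=O)c2C#N)cc1` gives 224000 nM
Compound 3 `O=C1Nc2ccc(S(=O)(=O)N3CCOCC3)cc2/C1=N/c1ccc(/N=C2\C(=O)Nc3ccc(S(=O)(=O)N4CCOCC4)cc32)cc1` gives 203000 nM

These three values come from an ADME assay on WI-38 cells (Homo sapiens) for cytotoxicity, read by sulforhodamine B assay, with a stated time of 24 h (a lower number here means a stronger inhibitor, a higher number a weaker inhibitor), and sit close together. Compound 1 (at 309000 nM) lies within the usual scatter of both compound 2 and compound 3, so the numbers give no order among the three.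

Compound 4 `O=C1Nc2ccc(S(=O)(=O)N3CCOCC3)cc2/C1=N/c1ccc(C(=O)O)cc1` has not been measured yet. It keeps the core of compound 1 and differs in one place: carboxy in place of methyl on an aromatic carbon. In words, this is carboxy in place of methyl on an aromatic carbon, para to a large group, so 4-methylphenyl becomes 4-carboxyphenyl.

Among the compounds with values here, no two measured compounds differ in just one place, so the data hold no direct example of a swap like this one. The nearest guide is a broader comparison. Compound 3 (at 203000 nM) differs from compound 1 by far more than one small group, yet the two values stay within the scatter.

A change beyond the scatter is therefore not expected in this assay, in either direction. The expected change is small, a 1.2-fold lower number from compound 1 to compound 4 (0.09 log units; within the scatter), and no larger than the scatter. Compound 4 is estimated at 250000 nM (120000 nM to 450000 nM).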

Compound 4, half-maximal inhibitory concentration: 313000 nM
For compound 4 the middle estimate is 1.3-fold (0.10 log units) below the measured one; the measured number falls inside the stated range.
By their numbers in this assay, from the lowest: compounds 3, 2, 1 and 4 (each within the scatter of the next).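

Within the data shown here, compound 1 and compound 4 are the first pair here that differ in one place only, so this swap can now be read directly rather than through a broader comparison. In this assay the change is a 1.0-fold higher number from compound 1 to compound 4 (0.01 log units; within the scatter) when carboxy replaces methyl on an aromatic carbon, para to a large group. At this position, then, going from 4-methylphenyl to 4-carboxyphenyl adds one hydrogen-bond donor and one hydrogen-bond acceptor, and the two compounds still cannot be told apart in this assay. No measurement at hand speaks to why that is so.

As far as these compounds go, with a single step at a single position, it remains open whether an amine, a methyl ester or a longer alkyl chain in the same place would also stay within the scatter of compound 1. Among these compounds, it also remains open whether the same swap from methyl to carboxy would leave the number unchanged on a core other than the one shared by compound 1 and compound 4.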